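The compounds below may be only part of what the source reports. "The series", "measured", "known", "first", "only" and "open" are said of these compounds alone.

The series shares one core carrying a diaryl ether whose outer ring varies. Compound 1 `Cc1ccccc1Oc1ccc(N2C[C@@H](C(F)(F)F)C[C@H]2CC(=O)O)cc1` gives 73 nM in a functional assay on cells for agonist activity at Free fatty acid receptor 1 (Homo sapiens), read by FLIPR and calcium flux, with a stated time of 100 s; a lower number here means that less compound is needed, a higher number that more compound is needed for the effect. Compound 2 `COc1ccc(Oc2ccc(N3C[C@@H](C(F)(F)F)C[C@H]3CC(=O)O)cc2)c(C)c1` gives 55 nM in this assay, and compound 3 `Cc1cccc(Oc2ccc(N3C[C@@H](C(F)(F)F)C[C@H]3CC(=O)O)cc2)c1C` gives 110 nM. Compound 3 holds the highest of the three numbers, but the step of a 1.5-fold higher number from compound 1 to compound 3 (0.18 log units; within the scatter) and the step of a 2.0-fold higher number from compound 2 to compound 3 (0.30 log units; within the scatter) both fall within the scatter, so no order among the three can be read from these values.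

Compound 4 `Cc1c(Cl)cccc1Oc1ccc(N2C[C@@H](C(F)(F)F)C[C@H]2CC(=O)O)cc1` differs from compound 3 by chloro in place of methyl on an aromatic carbon, ortho to a methyl group and meta to a large group. For the measured compounds named here, no measured step exchanges a methyl for a chloro; the closest precedents are other substituent changes on the same outer ring, a 1.3-fold lower number from compound 1 to compound 2 (0.12 log units; within the scatter) and a 1.5-fold higher number from compound 1 to compound 3 (0.18 log units; within the scatter), each within the scatter. The step from compound 3 to compound 4 is therefore expected to be small, a 1.1-fold lower number from compound 3 to compound 4 (0.04 log units; within the scatter), with no direction beyond the scatter. Compound 4 is estimated at 100 nM, in the range 45 nM to 220 nM.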

Compound 4, half-maximal effective concentration: 82 nM
For compound 4 the middle estimate is 1.2-fold (0.09 log units) above the measured one, within the range that was stated.
By their numbers in this assay, from the lowest: compounds 2, 1, 4 and 3 (each within the scatter of the next).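

In this assay the position ortho to a methyl group and meta to a large group carries chloro, methyl or hydrogen with no readable difference: there is a 1.3-fold lower number from compound 3 to compound 4 (0.13 log units; within the scatter) and a 1.1-fold higher number from compound 1 to compound 4 (0.05 log units; within the scatter) for the two exchanges at this position. Set against the outer ring of compound 2, the 3-chloro-2-methylphenyl group gives a 1.5-fold higher number from compound 2 to compound 4 (0.17 log units; within the scatter) and does not separate from it either, so chloro joins methyl and methoxy as changes on this ring that stay inside the scatter. No measurement of any property bears on these steps, and no cause can be assigned to them.

Going by these compounds, whether a nitrile, an amine or a longer chain such as propyl at this position would move the number beyond the scatter remains open. Also open, on these data alone, is whether bromo or fluoro would behave as chloro does here.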